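Notes on adding chloro to compound 2

The source may report more compounds than this note shows. Statements on the series, on what has been measured and on what is new or still open speak of the compounds shown alone.

- compound 1 `O=C(CCCCC1CCSS1)Nc1cccc2ccccc12` gives 9.55%
- compound 2 `CC(=O)SCCC(CCCCC(=O)Nc1ccccc1)SC(C)=O` gives 2.84%

Both values come from a functional assay on Bel-7402 cells (Homo sapiens) for inhibition, read by MTT assay, with a stated time of 24 h, tested at 1 ug/mL (a lower number here means less inhibition of growth, a higher number more inhibition of growth at the concentration tested), and compound 2 stands within the scatter of compound 1. Within the data shown here, these two compounds differ in more than one place, and no measured pair shows what a ring substituent does. Compound 3 `CC(=O)SCCC(CCCCC(=O)Nc1cccc(Cl)c1)SC(C)=O` has chloro in place of hydrogen on an aromatic carbon, phenyl to 3-chlorophenyl, with chloro in place of hydrogen on an aromatic carbon as the counted change. The expected step of a number 3.2 percentage points higher from compound 2 to compound 3 (within the scatter) is small, upward if anything, and not beyond the scatter. In this assay compound 3 is estimated at 6% with 0% to 16% as the expected range.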

Compound 3, percent growth inhibition at one concentration: 0.56%
The estimate for compound 3 lay 5.4 percentage points above the measured number; measured number inside the range.
By their numbers in this assay, from the lowest: compounds 3, 2 and 1 (each within the scatter of the next).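

In this assay, among these compounds, this is the first measured pair for a ring substituent: phenyl to 3-chlorophenyl, with chloro in place of hydrogen on an aromatic carbon meta to a large group, gives the step (a number 2.3 percentage points lower from compound 2 to compound 3 (within the scatter)). At this position, the change cannot be told apart from the unsubstituted phenyl. No measurement at hand bears on the reason for this result.

From the compounds shown here alone, whether a methoxy group or an amine on the same aromatic carbon would give a step beyond the scatter remains open. So does whether chloro elsewhere on the ring would.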